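A few compounds are considered here, and "the series" means these few. Any claim that something is new, unique, unknown or untested is made for them only; others in the source may bear on it.

Measured so far:
Compound 1 `Cc1cc(-c2cc(C)c(OC[C@@](C)(N)CC(C)C)cn2)ccn1` gives 4.7 nM in an assay on brain (strain C57BL6) for displacement of a labelled ligand from AP2-associated protein kinase 1 (Mus musculus), read by scintillation counting, with a stated time of 1 h; a higher number here means a weaker inhibitor, a lower number a stronger inhibitor.
Compound 2 `COC(=O)Nc1cc(-c2cc(Cl)c(OC[C@@](C)(N)CC(C)C)cn2)ccn1` gives 0.11 nM in this assay.
Compound 3 `CC(=O)Nc1cc(-c2ccc(OC[C@@H](N)CC(C)C)c(F)c2)ccn1` gives 0.52 nM in this assay.

Compound 2 holds the lowest number of the three; compound 3 stands nearest, and compound 1 lies furthest from it, both gaps beyond the scatter. Compound 4 `Cc1cc(-c2cc(Cl)c(OC[C@@](C)(N)CC(C)C)cn2)ccn1` has not yet been measured in this assay. It differs from compound 2 in one place: methyl in place of (methoxycarbonyl)amino on an aromatic carbon. Compound 1 carries the same methyl on that ring and shows 4.7 nM, so the step is expected to raise the number well beyond the scatter, the expected size being an 18-fold higher number from compound 2 to compound 4 (1.26 log units; beyond the scatter). Compound 4 is therefore estimated at 2 nM, within a range from 0.5 nM to 8 nM.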

Compound 4, inhibition constant: 0.7 nM
Estimate against measurement, compound 4: 2.9-fold (0.46 log units) above; the range from low to high includes it.
By their numbers in this assay, from the lowest: compound 2; then compounds 3 and 4 (each within the scatter of the next); then compound 1.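

With the chloro group held constant, a 6.4-fold higher number from compound 2 to compound 4 (0.80 log units; beyond the scatter) shows in this assay that replacing (methoxycarbonyl)amino with methyl next to the ring nitrogen weakens binding beyond the scatter, though compound 4 stays at 0.7 nM without the carbamate-bearing group. With that methyl held constant, a 6.7-fold lower number from compound 1 to compound 4 (0.83 log units; beyond the scatter) shows that chloro in place of methyl on the other aromatic carbon independently strengthens binding. No available evidence bears on the reason for either step. Open, going by these compounds, is how an amine or an ethyl group would behave at the position next to the ring nitrogen, and whether chloro gives the same gain alongside (methoxycarbonyl)amino.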